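One Extra Methyl on the Chain of Compound 3

A few compounds are considered here, and "the series" means these few. Any claim that something is new, unique, unknown or untested is made for them only; others in the source may bear on it.

Compound 1 `O=C(CCCCCNc1c(NCc2ccccc2)c(=O)c1=O)NO` and compound 2 `C[C@@H](Nc1c(NCCCCCC(=O)NO)c(=O)c1=O)c1ccccc1` share one core. In a physicochemical assay for solubility, read by HPLC, in phosphate buffer, with a stated time of 24 h, at pH 7.4, tested at 100 uM (a lower number here means a less soluble compound, a higher number a more soluble compound), compound 1 gives 75000000 nM, and compound 2 gives 80000000 nM. The change between them is methyl in place of hydrogen on a saturated chain carbon bound to an aromatic carbon and a nitrogen on an aromatic ring, and it made a 1.1-fold higher number from compound 1 to compound 2 (0.03 log units; within the scatter). Compound 3 `CCC(CCCCC(=O)NO)Nc1c(Nc2ccc(C(F)(F)F)cc2)c(=O)c1=O` carries a different core; how its core differs from that of compound 1 is not broken down here. In this assay compound 3 gives 6600000 nM, the lowest of the three numbers. Compound 4 `CC(C)C(CCCCC(=O)NO)Nc1c(Nc2ccc(C(F)(F)F)cc2)c(=O)c1=O` differs from compound 3 by methyl in place of hydrogen on a saturated chain carbon bound to two saturated chain carbons. Within the data shown here, this is the same kind of change as the one between compound 1 and compound 2, but the place differs: there the carbon is bound to an aromatic carbon and a nitrogen on an aromatic ring, here to two saturated chain carbons. The expected step is a 1.3-fold lower number from compound 3 to compound 4 (0.12 log units; within the scatter), resting on the earlier 1.1-fold higher number from compound 1 to compound 2 (0.03 log units; within the scatter). Compound 4 is therefore estimated at 5000000 nM, between 2000000 nM and 12000000 nM.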

Compound 4, solubility: 5300000 nM
Compound 4: middle estimate off by 1.1-fold (0.03 log units), on the low side; the measured number falls inside the stated range.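

In this assay the methyl-for-hydrogen change gives a 1.2-fold lower number from compound 3 to compound 4 (0.10 log units; within the scatter), and on the core of compound 1 it gave a 1.1-fold higher number from compound 1 to compound 2 (0.03 log units; within the scatter), so on both cores the step stays within the scatter. Among these compounds, these are only two pairs and the carbon that takes the methyl differs between them, so they do not show that the change would behave the same way on other cores or at other places. Nothing given here bears on why the numbers behave this way.

The compounds shown leave open what an amine, a carboxylic acid or a longer chain would do in place of the methyl on a saturated chain carbon bound to two saturated chain carbons. They also leave open whether such a group would give a step beyond the scatter.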